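A few compounds are considered here, and "the series" means these few. Any claim that something is new, unique, unknown or untested is made for them only; others in the source may bear on it.

Measured in an ADME assay on LL24 cells (Homo sapiens) for inhibition, read by MTT assay, with a stated time of 24 h; a higher number here means a weaker inhibitor, a lower number a stronger inhibitor:
- Compound 1 `CCCOc1ccc(C(=O)N/N=C/c2ccc([N+](=O)[O-])o2)cc1`: > 200000 nM, a limit of the assay and not a number.
- Compound 2 `CCCCNc1ccc(C(=O)N/N=C/c2ccc([N+](=O)[O-])o2)cc1`: 47000 nM.

Within the data shown here, compound 2, at 47000 nM, holds the only actual number so far. The next structure is compound 3 `O=C(N/N=C/c1ccc([N+](=O)[O-])o1)c1ccc(Cl)cc1`, with chloro in place of butylamino on an aromatic carbon.

Among the measured compounds shown here, one measured step bears on this change. Butylamino in place of propoxy on an aromatic carbon gave an at least 4.2-fold lower number from compound 1 to compound 2 (0.62 log units; beyond the scatter). This single pair links butylamino with the lower number, so it is thin support. With butylamino leaving, a move of similar size towards a higher number in this assay is expected, likely beyond the scatter. The expected change is a 3.0-fold higher number from compound 2 to compound 3 (0.47 log units; beyond the scatter). For compound 3 the estimated value is 140000 nM, with an expected range of 60000 nM to 200000 nM.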

Compound 3, half-maximal inhibitory concentration: 187000 nM
The estimate for compound 3 lay 1.3-fold (0.13 log units) below the measured number, within the range that was stated.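

In this assay, the position para to a large group now has actual numbers at both ends of a step: chloro in place of butylamino gives a 4.0-fold higher number from compound 2 to compound 3 (0.60 log units; beyond the scatter). Among these compounds, the earlier step gave only a floor, so this is the first measured size for a change away from butylamino, and it again leaves butylamino with the lower number. Against propoxy, chloro shows an at least 1.0-fold lower number from compound 1 to compound 3 (0.02 log units; that floor lies within the scatter), which does not order the two, as compound 1 sits at a limit of the assay: the limit of > 200000 nM in this assay, at which 1 of the 3 values shown sits.

The lower number still rests on butylamino alone, in compound 2. Going by these compounds, whether an unsubstituted amine, a shorter alkylamino chain or a plain butyl chain without the nitrogen would keep that number remains open.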